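A 4-nitrobenzyl group replaces 3-bromo-4-methylphenyl in compound 4

This account rests on a few compounds, and the source may have more. Where it says the series, first, only, none or still open, it means among the compounds named here.

Compound 1 `COc1ccc(-n2cc(COc3ccc(/C=C/C(=O)c4ccc5c(c4O)CCC(C)(C)O5)cc3)nn2)c([N+](=O)[O-])c1` gives 132000 nM
Compound 2 `CCc1ccccc1-n1cc(COc2ccc(/C=C/C(=O)c3ccc4c(c3O)CCC(C)(C)O4)cc2)nn1` gives "not active" (no number reported)
Compound 3 `Cc1ccc(-n2cc(COc3ccc(/C=C/C(=O)c4ccc5c(c4O)CCC(C)(C)O5)cc3)nn2)cc1Br` gives "not active" (no number reported)

In a functional assay on IMR-32 cells (Homo sapiens) for antiproliferative activity, read by MTT assay (a higher number here means a weaker inhibitor, a lower number a stronger inhibitor), compound 3 stands at "not active" (no number reported) and so has no single number. Compound 2 is the one further entry of that kind. Compound 4 `CC1(C)CCc2c(ccc(C(=O)/C=C/c3ccc(OCc4cn(Cc5ccc([N+](=O)[O-])cc5)nn4)cc3)c2O)O1` carries 4-nitrobenzyl in place of 3-bromo-4-methylphenyl on an aromatic nitrogen, and the counted change is 4-nitrobenzyl in place of 3-bromo-4-methylphenyl on an aromatic nitrogen here. Among the compounds with values here, with no measured step to lean on, only a modest shift is expected, at best into weak measurable activity, since compound 1 reads 132000 nM as the sole number in this set. A result without a number remains quite possible. Compound 4 is estimated at 70000 nM (expected range 15000 nM to 250000 nM).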

Compound 4, half-maximal inhibitory concentration: 17300 nM
For compound 4 the middle estimate is 4.0-fold (0.61 log units) above the measured one; measured number inside the range.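

In this assay a 4-nitrobenzyl group on the aromatic nitrogen gives compound 4 a measurable value, where 3-bromo-4-methylphenyl at this position leaves compound 3 without a number. Against 4-methoxy-2-nitrophenyl, 4-nitrobenzyl gives a 7.6-fold lower number from compound 1 to compound 4 (0.88 log units; beyond the scatter) and so shows that the group at this position can move the read-out beyond the scatter. No measured evidence here explains this difference.

The compounds shown leave open whether an unsubstituted benzyl would keep this activity. They also leave open how a benzyl bearing an amine or a carboxylic acid would behave.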